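The compounds below may be only part of what the source reports. "The series", "measured", "known", "first", "only" and "open" are said of these compounds alone.

Among the measured compounds shown here, only two compounds with this core have been tested so far in a functional assay on HCC827 cells (Homo sapiens) for cytotoxicity, read by MTT assay, with a stated time of 72 h; a higher number here means a weaker inhibitor, a lower number a stronger inhibitor. In this assay, compound 1 `CN1CCN(c2ccc(Nc3ncc4nc(Nc5ccccc5)n(C5CCCCC5)c4n3)cc2)CC1` gives < 0.01 nM, which is a limit of the assay and not a number. Compound 2 `CN1CCN(c2ccc(Nc3ncc4nc(Nc5cccc([N+](=O)[O-])c5)n(C5CCCC5)c4n3)cc2)CC1` gives < 0.01 nM, which is also a limit. Compound 2 therefore has no exact value, and its place is given only by the limit of < 0.01 nM in this assay, at which 2 of the 2 values shown sit.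

Compound 3 `CN1CCN(c2ccc(Nc3ncc4nc(Nc5cccc(Cl)c5)n(C5CCCC5)c4n3)cc2)CC1` differs from compound 2 in one place, with chloro in place of nitro on an aromatic carbon, meta to a large group: chloro in place of nitro on an aromatic carbon. For the measured compounds named here, no measured pair shows the size of this change, so the expectation rests on compound 2 and its limit of < 0.01 nM. The expected step of a number no lower from compound 2 to compound 3 (the limit leaves the size open) is none beyond the scatter, with neither direction favoured. For compound 3, the estimated value is 0.01 nM, with an expected range from 0.003 nM to 0.3 nM.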

Compound 3, half-maximal inhibitory concentration: < 0.01 nM
Compound 3 was reported as a limit; the forecaster's own chance of this, stated with the estimate: 65%; the middle value lies on the limit itself.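

In this assay compound 3 gives < 0.01 nM, which is a limit of the assay and not a number. Compound 2 is also reported as a limit, so no step can be read between compound 2 and compound 3: the limit of < 0.01 nM in this assay, at which 3 of the 3 values shown sit.

As far as these compounds go, whether chloro in place of nitro changes the true potency at all, and in which direction, stays open.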